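An aryl swap on compound 1

The source may hold more compounds than are shown below. What is called first, only, known or untested is meant among the compounds shown, and "the series" means these compounds.

compound 1 `Fc1ccccc1NC(=S)N/N=C/c1ccc2ccccc2n1`: > 100000 nM
compound 2 `NC(=S)N/N=C/c1cc2ccccc2s1`: 99200 nM
compound 3 `NC(=S)N/N=C/c1nc2ccccc2s1`: > 100000 nM

In a functional assay on HT-29 cells (Homo sapiens) for antiproliferative activity, read by sulforhodamine B assay, with a stated time of 72 h (on this read-out lower numbers stand for stronger inhibition and higher numbers for weaker inhibition), compound 1 gives > 100000 nM, which is a limit and not a number. Compound 3 gives > 100000 nM, which is also a limit. Among the compounds with values here, compound 2 gives 99200 nM, the only true number among the three. As far as these compounds go, compound 1 therefore stands at the limit of > 100000 nM in this assay, at which 2 of the 3 values shown sit, and how far it lies beyond that limit is unknown.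

The next compound, compound 4 `Cc1ccc(NC(=S)N/N=C/c2ccc3ccccc3n2)cc1`, carries 4-methylphenyl in place of 2-fluorophenyl on an amide-type nitrogen. Within the data shown here, no measured pair shows what a change of this kind does in this assay. At most a modest step toward stronger inhibition is expected, and compound 4 may well remain at the limit. Among the measured compounds shown here, this expectation leans on compound 2, whose 99200 nM is the only measured number available. The expected size of the change is an at least 2.0-fold lower number from compound 1 to compound 4 (0.30 log units; that floor lies within the scatter). Compound 4 is estimated to give 50000 nM, with an expected range of 8000 nM to 100000 nM.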

Compound 4, half-maximal inhibitory concentration: 85500 nM
The estimate for compound 4 lay 1.7-fold (0.23 log units) below the measured number; low and high end bracket the measured number.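

With 4-methylphenyl in place of 2-fluorophenyl on the amide-type nitrogen, compound 4 gives 85500 nM in this assay, showing that a change at this place alone can bring the core of compound 1 to a true number. Compound 1 gives > 100000 nM, which is a limit. The change amounts to an at least 1.1-fold lower number from compound 1 to compound 4 (0.06 log units; that floor lies within the scatter), and its real size remains unknown because one end of the step is a limit: the limit of > 100000 nM in this assay, at which 2 of the 4 values shown sit.

The compounds shown leave open whether any group on this nitrogen can move the core of compound 1 far from the top of the measurable range. They also do not show what a 4-methoxyphenyl group, a 4-carboxyphenyl group or a longer alkyl chain would do at this place.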